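This account rests on a few compounds, and the source may have more. Where it says the series, first, only, none or still open, it means among the compounds named here.

Measured so far:
Compound 1 `Cc1noc(C)c1S(=O)(=O)N1CCC(N2CCC(C)CC2)CC1` in an ADME assay on HCT-116 cells (Homo sapiens) for cytotoxicity, read by CellTiter-Glo, with a stated time of 72 h; on this read-out lower numbers stand for stronger inhibition and higher numbers for weaker inhibition: > 10000 nM
Compound 2 `COc1ccc(NC(=O)N2CCC(N3CCC(C)CC3)CC2)cc1` in this assay: > 5000 nM

Compound 1 stands at the upper end of what this assay reports. Its value of > 10000 nM is a limit of the assay and not a number (the limit of > 10000 nM in this assay, at which 1 of the 2 values shown sits). Compound 2 likewise gives > 5000 nM, which is also a limit (the limit of > 5000 nM in this assay, at which 1 of the 2 values shown sits). Among the measured compounds shown here, compound 1 and compound 2 differ in more than one place, so no step between them can be drawn; together their values show only that neither reaches a measurable inhibitory concentration here.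

Compound 3 `Cc1nc(Cl)sc1S(=O)(=O)N1CCC(N2CCC(C)CC2)CC1` has not yet been measured. It differs from compound 1 in one place: 2-chloro-4-methyl-1,3-thiazol-5-yl in place of 3,5-dimethyl-1,2-oxazol-4-yl on a sulfonyl sulfur. Because compound 1 sits at a limit (the limit of > 10000 nM in this assay, at which 1 of the 2 values shown sits), no direction can be read from the numbers shown. The step expected for compound 3 is a step that the limit leaves unreadable from compound 1 to compound 3, meaning none beyond the scatter. Compound 3 is therefore estimated at 15000 nM, within a range from 4000 nM to 60000 nM, and it is expected that this assay will most likely again report only a limit for it.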

Compound 3, half-maximal inhibitory concentration: > 10000 nM
Compound 3: no number, only a limit; the forecaster's own chance of this, stated with the estimate: 85%; the middle value lies beyond the limit too.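

In this assay compound 3 gives > 10000 nM as a limit of the assay and not a number. Compound 1 also sits at a limit, so no step can be read between compound 1 and compound 3. The compounds shown leave open whether 2-chloro-4-methyl-1,3-thiazol-5-yl in place of 3,5-dimethyl-1,2-oxazol-4-yl changes inhibition at all.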